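Swapping Chloro for Methyl in a Cytotoxicity Series

The compounds below may be only part of what the source reports. "The series", "measured", "known", "first", "only" and "open" are said of these compounds alone.

Of the compounds shown here, three have so far been tested in a toxicity assay on THP-1 cells (Homo sapiens) for inhibition; on this read-out lower numbers stand for higher toxicity in this test and higher numbers for lower toxicity in this test. Compound 1 `Cc1ccc(-c2cnc(NC(=O)c3ccc(F)cc3)n2C)cc1` gives 60000 nM. Compound 3 `Cn1c(-c2ccc(Cl)cc2)cnc1NC(=O)c1ccc(F)cc1` gives 37000 nM. Compound 2 `O=C(Nc1ncc(-c2ccccc2)o1)c1ccc(Cl)cc1` gives 10000 nM, the lowest of the three numbers; its nearest neighbour is compound 3 and the furthest is compound 1, and both of those gaps lie beyond the scatter. Compounds 1 and 3 share one core and differ in a single place: methyl in place of chloro on an aromatic carbon. This change gave a 1.6-fold higher number from compound 3 to compound 1 (0.21 log units; within the scatter). Compound 2 is built on a different core, and how that core differs from the core of compound 3 is not broken down here.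

Compound 4 `Cc1ccc(C(=O)Nc2ncc(-c3ccccc3)o2)cc1` has not yet been measured. It arises from compound 2 by the same change: methyl in place of chloro on an aromatic carbon. In this assay compound 4 is expected to give about 14000 nM, most likely between 7000 nM and 30000 nM. That expectation rests on compound 2 giving 10000 nM and on the earlier step of a 1.6-fold higher number from compound 3 to compound 1 (0.21 log units; within the scatter). The step estimated for compound 4, a 1.4-fold higher number from compound 2 to compound 4 (0.15 log units; within the scatter), is therefore expected to stay within the scatter.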

Compound 4, half-maximal cytotoxic concentration: 26000 nM
Compound 4: the middle estimate sits 1.9-fold (0.27 log units) below what was measured; the measured number falls inside the stated range.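

In this assay, methyl in place of chloro gave a 2.6-fold higher number from compound 2 to compound 4 (0.41 log units; beyond the scatter), a modest step. Set beside the earlier case, the size of the change carries over from one core to the other, as far as the scatter allows: the same change on two cores in this assay, a 1.6-fold higher number (0.21 log units; within the scatter) from compound 3 to compound 1 and a 2.6-fold higher number (0.41 log units; beyond the scatter) from compound 2 to compound 4, 1.6-fold (0.21 log units) apart, within the scatter of two such steps. This makes the earlier step a fair rough guide within this small series, but two pairs of compounds do not establish a rule, only the newer step lies beyond the scatter, and neither pair says why the number moves.

The compounds shown leave open how this assay would respond to other groups at the same place on the ring, such as an amine, a carboxylic acid or a longer chain, since only chloro and methyl appear there in these pairs. They also leave open whether the swap from chloro to methyl would give a step of similar size on any core beyond these two.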